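A few compounds are considered here, and "the series" means these few. Any claim that something is new, unique, unknown or untested is made for them only; others in the source may bear on it.

Measured in a functional assay on thoracic aorta (Rattus norvegicus, strain Wistar), with a stated time of 15 min; on this read-out higher numbers stand for an effect only at larger amounts of compound and lower numbers for an effect already at smaller amounts:
- compound 1 `COc1ccc(Cl)cc1C(C)NC(=O)NS(=O)(=O)c1ccccc1`: > 300000 nM (a limit of the assay, not a number)
- compound 2 `COc1ccc(Cl)cc1C(C)NC(=O)N(C)S(=O)(=O)c1ccc(Cl)cc1`: 20000 nM

Of these two entries, only compound 2 has an actual number, 20000 nM, so it has no measured neighbour to be ranked against. The other entry is a limit, recorded for compound 1: the limit of > 300000 nM in this assay, at which 1 of the 2 values shown sits.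

Compound 3 `COc1ccc(Cl)cc1C(C)NC(=O)NS(=O)(=O)c1ccc(Cl)cc1` is the next one to read. Going to it from compound 2 changes one place, with hydrogen in place of methyl on an amide-type nitrogen. For the measured compounds named here, no measured step isolates this change, so the expectation rests on thin ground.

That hydrogen is also present in compound 1, whose > 300000 nM is a limit. A move towards higher numbers in this assay is therefore expected, beyond the usual scatter but with wide uncertainty. The expected size is a 3.5-fold higher number from compound 2 to compound 3 (0.54 log units; beyond the scatter). A reading that returns only a limit would not be surprising.

For compound 3 the estimate is 70000 nM, with an expected range of 15000 nM to 300000 nM.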

Compound 3, half-maximal effective concentration: > 300000 nM
Compound 3 ended at the assay's limit; the forecaster's own chance of this, stated with the estimate: 35%; middle value at least 4.2-fold (0.63 log units) from the limit.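

In this assay, the methyl on the amide-type nitrogen, whose other neighbours are the carbonyl carbon and the sulfonyl sulfur, now has a measured step: hydrogen in its place gives an at least 15-fold higher number from compound 2 to compound 3 (1.17 log units; beyond the scatter). For the compounds shown here, compound 1 and compound 2 differ in more than one place, so this is the first comparison that isolates this nitrogen, and it does so with the chloro on the aromatic carbon held constant. Of the compounds shown, only the one with methyl on this nitrogen gives a number, while both with hydrogen there end at a limit, so the step has a lower bound but no full size: the limit of > 300000 nM in this assay, at which 2 of the 3 values shown sit.

From the compounds shown here alone, the step from compound 1 to compound 3 cannot be read, as both values are limits, and the contribution of the chloro on the aromatic carbon stays open among the compounds with hydrogen on this nitrogen. An ethyl group or a longer chain on this nitrogen would show whether the number from compound 2 depends on methyl itself or extends to other alkyl groups.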